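Chloro to Fluoro on a Shared Anilino Core

A few compounds are considered here, and "the series" means these few. Any claim that something is new, unique, unknown or untested is made for them only; others in the source may bear on it.

Compounds measured so far:
compound 1, `Fc1ccc(Nc2nnc(COc3ccc(-c4ccccc4)cc3)o2)cc1`, 52.3%
compound 2, `Clc1ccc(Nc2nnc(COc3ccc(-c4ccccc4)cc3)s2)cc1`, 54.5%

In a functional assay on the whole organism (strain Wistar) for inhibition, with Rattus norvegicus as the target, read by paw edema, with a stated time of 4 h, at a dose of 10 mg/kg by the oral route (a lower number here means less inhibition, a higher number more inhibition at the dose given (going by the name of the read-out)), compound 2 gives 54.5%, the larger of the two numbers, while compound 1 with 52.3% lies within the scatter of it, so the two cannot be told apart. Among the compounds with values here, no pair of measured compounds differs in one place only, so no single step can be read from them. Compound 3, `Fc1ccc(Nc2nnc(COc3ccc(-c4ccccc4)cc3)s2)cc1`, is not yet measured; it differs from compound 2 by fluoro in place of chloro on an aromatic carbon. The step from compound 2 to compound 3 is expected to be none beyond the scatter. Compound 3 is therefore estimated at 52%, between 40% and 64%, an expected step of a number 2.5 percentage points lower from compound 2 to compound 3 (within the scatter).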

Compound 3, a percentage reported as inhibition, in the whole organism at one dose (the size of the read-out at that dose, not a potency): 29.5%
Compound 3: middle estimate off by 22.5 percentage points, on the high side, outside the stated range (below it).
By their numbers in this assay, from the lowest: compound 3; then compounds 1 and 2 (each within the scatter of the next).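

In this assay the exchange of 4-chlorophenyl for 4-fluorophenyl gives a number 25 percentage points lower from compound 2 to compound 3 (beyond the scatter), so the choice of halogen on this aromatic carbon, para to a large group, clearly matters. The earlier compounds shown here could not show this, as they differed in more than one place. Nothing available accounts for this step.

On these data alone, it remains open how a methyl, a methoxy or an amine would fare on this carbon, and whether the same exchange would give a similar step on the core of compound 1.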